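The source may hold more compounds than are shown below. What is called first, only, known or untested is meant among the compounds shown, and "the series" means these compounds.

Compound 1 `NC(=O)c1ccc(-c2cnc3ccc(-c4cccc(S(=O)(=O)C5CC5)c4)nn23)cc1`: in a physicochemical assay for solubility, at pH 6.5 (on this read-out lower numbers stand for lower solubility and higher numbers for higher solubility), compound 1 gives < 5000 nM, which is a limit of the assay rather than a number.
Compound 2 `CS(=O)(=O)c1cncc(-c2ccc3ncc(-c4ccc(S(=O)(=O)C5CC5)cc4)n3n2)c1`: compound 2 gives < 5000 nM, again a limit.
Compound 3 `CS(=O)(=O)c1ccc(-c2cnc3ccc(-c4cncc(C(F)(F)F)c4)nn23)cc1`: compound 3 gives < 5000 nM, also a limit.

Compound 3 thus stands where every measured value here stands, at the limit of < 5000 nM in this assay, at which 3 of the 3 values shown sit, and no exact number is known for it. Compound 4 `CS(=O)(=O)c1ccc(-c2cnc3ccc(-c4cncc(S(C)(=O)=O)c4)nn23)cc1` differs from compound 3 in one place: methylsulfonyl in place of trifluoromethyl on an aromatic carbon. No measured pair among these compounds shows a step of this kind, so the change gives no direction in this assay. The step is expected to be small, not beyond the scatter: a step that the limit leaves unreadable from compound 3 to compound 4. Compound 4 is expected at 3500 nM, within a range from 800 nM to 15000 nM, and most likely reported again only as a limit.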

Compound 4, solubility: < 5000 nM
Compound 4 gave a limit, no number; the forecaster's own chance of this, stated with the estimate: 70%; the middle value lies beyond the limit too.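

Neither the step from compound 3 to compound 4 nor the one from compound 2 to compound 4 can be read, because all these values are limits, not numbers: the limit of < 5000 nM in this assay, at which 4 of the 4 values shown sit.

From the compounds shown here alone, the exact value of each compound in this assay stays open, and so does whether either change moves it at all.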